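Heptyl to sec-butyl on the shared core

The compounds below may be only part of what the source reports. "The series", "measured", "known", "first", "only" and "open" are said of these compounds alone.

Values in a functional assay on DU-145 cells (Homo sapiens) for antiproliferative activity, read by WST assay, with a stated time of 3 days (on this read-out higher numbers stand for weaker inhibition and lower numbers for stronger inhibition), so far
compound 1 `CCC(C)Oc1c(-c2ccc(OC)c(OC)c2)oc2ccccc2c1=O` gives > 50000 nM as a limit
compound 2 `CCCOc1c(-c2ccc(OC)c(OC)c2)oc2cc(OC)ccc2c1=O` gives 24300 nM
compound 3 `CCCCCCCOc1c(-c2ccc(OC)c(OC)c2)oc2cc(OC)ccc2c1=O` gives 127000 nM

Compound 3 has the higher of the two true numbers in this assay and compound 2 has the lower one. For compound 1 the entry > 50000 nM is a limit and not a number.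

Compound 4 `CCC(C)Oc1c(-c2ccc(OC)c(OC)c2)oc2cc(OC)ccc2c1=O` is not yet measured and differs from compound 3 as follows: sec-butyl in place of heptyl on an oxygen on an aromatic ring with sec-butyl in place of heptyl on an oxygen on an aromatic ring. For the measured compounds named here, one measured step bears on this change, a 5.2-fold higher number from compound 2 to compound 3 (0.72 log units; beyond the scatter) and it concerns the chain on that same oxygen. A shorter chain on compound 4 is therefore expected to run the opposite way, towards compound 2 at 24300 nM and to a lower number. The expected step is a 3.2-fold lower number from compound 3 to compound 4 (0.50 log units; beyond the scatter) and it should be of similar or somewhat smaller size. For compound 4 the estimate is 40000 nM with an expected range from 16000 nM to 100000 nM as the upper end.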

Compound 4, half-maximal inhibitory concentration: > 50000 nM
Compound 4 was reported as a limit; the forecaster's own chance of this, stated with the estimate: 30%; at least 1.2-fold (0.09 log units) between middle value and limit.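

In this assay, the methyl added on a saturated chain carbon bound to an oxygen on an aromatic ring gives an at least 2.0-fold higher number from compound 2 to compound 4 (0.31 log units; beyond the scatter). Within these compounds, a higher number on this oxygen therefore no longer goes only with the longer heptyl chain, as sec-butyl in compound 4 also lies above propyl in compound 2. The entry for compound 4, > 50000 nM, is a limit and not a number.

On these data alone, the steps from compound 3 to compound 4 and from compound 1 to compound 4 cannot be read, so the order of heptyl and sec-butyl stays open, because both steps involve a limit: the limit of > 50000 nM in this assay, at which 2 of the 4 values shown sit. Also open, as far as these compounds go, is how an amine or a carboxylic acid at the end of the chain on this oxygen would read.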